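Bridged diamine replacing cyclopropylpiperazine on the shared core

This account rests on a few compounds, and the source may have more. Where it says the series, first, only, none or still open, it means among the compounds named here.

Measured so far in a functional assay on CCRF-CEM cells for agonist activity at C-X-C chemokine receptor type 4 (Homo sapiens), read by calcium flux, with a stated time of 25 min; a higher number here means that more compound is needed for the effect, a lower number that less compound is needed:
Compound 1 `CN(C[C@H]1Cc2c(cccc2N2CCN(C3CC3)CC2)CN1)[C@H]1CCCc2cccnc21` gives > 30000 nM, a limit of the assay.
Compound 2 `CN(C[C@H]1Cc2c(cccc2N2CCN(Cc3ccccn3)CC2)CN1)[C@H]1CCCc2cccnc21` gives > 30000 nM, again a limit.
Compound 3 `CCN(C[C@H]1Cc2c(cccc2N2CCNCC2)CN1)[C@H]1CCCc2cccnc21` gives > 30000 nM, also a limit.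

Compound 1 therefore stands only at a limit in this assay, with no number to place it. Within the data shown here, the one step between measured compounds that differ in a single place, (pyridin-2-yl)methyl in place of cyclopropyl on an amine nitrogen in a ring, is a step that the two limits leave unreadable from compound 1 to compound 2 because of the limit of > 30000 nM in this assay, at which 3 of the 3 values shown sit. Compound 3 adds nothing readable either, as its value is likewise a limit.

Compound 4 `CN(C[C@H]1Cc2c(cccc2N2C[C@H]3C[C@@H]2CN3)CN1)[C@H]1CCCc2cccnc21` differs from compound 1 as follows: a group of 7 heavy atoms (5 carbon, 2 nitrogen; 2 five-membered non-aromatic rings with 1 hetero atom each) in place of a group of 9 heavy atoms (7 carbon, 2 nitrogen; one three-membered non-aromatic ring of carbon only, one six-membered non-aromatic ring with 2 hetero atoms), on an aromatic carbon. Among the measured compounds shown here, no measured step bears on this change; none of the three values gives a foothold for sizing any step in this assay, in either direction.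

On the numbers shown, the expectation for compound 4 is a value again at or near the limit, with the step that the limit leaves unreadable from compound 1 to compound 4 estimated only as a placeholder. The estimate for compound 4 is 50000 nM, with a range from 20000 nM to 200000 nM, and a high chance that only a limit is reported.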

Compound 4, half-maximal effective concentration: > 30000 nM
Compound 4: only a limit was reported (the forecaster's own chance of this, stated with the estimate: 80%); the middle value lies beyond the limit too.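

No step from compound 1 to compound 4 can be read in this assay, since both values are limits: the limit of > 30000 nM in this assay, at which 4 of the 4 values shown sit.

The compounds shown leave open how any change on the shared core would act in this assay, as none of them yet gives a measured number to compare.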